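Chloro to bromo at the weak end of the series

This account rests on a few compounds, and the source may have more. Where it says the series, first, only, none or still open, it means among the compounds named here.

Values in a functional assay on KYSE-450 cells (Homo sapiens) for inhibition, read by CCK-8 assay, with a stated time of 48 h (a higher number here means a weaker inhibitor, a lower number a stronger inhibitor), stand as follows
- compound 1 `COc1ccc(CN(C(=O)CSC(=S)N2CCN(C(=O)OC(C)(C)C)CC2)c2cc(OC)c(OC)c(OC)c2)cc1` gives 250 nM
- compound 2 `COc1ccc(CN(C(=O)CSC(=S)N2CCCc3cc(C)ccc32)c2cc(OC)c(OC)c(OC)c2)cc1` gives 5210 nM
- compound 3 `COc1ccc(CN(C(=O)CSC(=S)N2CCN(C(=O)OC(C)(C)C)CC2)c2ccc(Cl)cc2)cc1` gives > 20000 nM as a limit of the assay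

Compound 3 stands at the limit of > 20000 nM in this assay, at which 1 of the 3 values shown sits, and so has no number to step from. Compound 4 `COc1ccc(CN(C(=O)CSC(=S)N2CCN(C(=O)OC(C)(C)C)CC2)c2ccc(Br)cc2)cc1` carries bromo in place of chloro on an aromatic carbon with the rest unchanged. Within the data shown here, no measured step covers this swap. The nearest is an at least 80-fold higher number from compound 1 to compound 3 (1.90 log units; beyond the scatter) on the same amide-type nitrogen. Compound 4 also lacks the 3,4,5-trimethoxyphenyl group, so no step beyond the scatter is expected in this assay and no direction is favoured. The estimated step is a step that the limit leaves unreadable from compound 3 to compound 4 as an expectation only. Compound 4 is expected at 22000 nM with an estimated range of 8000 nM to 60000 nM for now.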

Compound 4, half-maximal inhibitory concentration: > 20000 nM
Compound 4: a limit, no number (the forecaster's own chance of this, stated with the estimate: 70%); the middle value is on the limit's open side.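

In this assay compound 4 gives > 20000 nM, a limit of the assay and not a number. The change from chloro to bromo cannot be read, as both halogen compounds stand at the limit: the limit of > 20000 nM in this assay, at which 2 of the 4 values shown sit. The 4-bromophenyl group repeats the 4-chlorophenyl result, with an at least 80-fold higher number from compound 1 to compound 4 (1.90 log units; beyond the scatter), so the large step on the amide-type nitrogen is not tied to chloro alone.

Open, on these data alone, is whether a 3,5-dimethoxyphenyl or 4-aminophenyl group on that nitrogen would return a value inside the assay's range. The halogen position itself stays unresolved while both compounds remain limits.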